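Compound 2 to compound 4: a methyl added

The compounds below may be only part of what the source reports. "The series", "measured", "known", "first", "only" and "open" are said of these compounds alone.

In an ADME assay on HeLa cells (Homo sapiens) for cytotoxicity (a lower number here means that less compound is tolerated, a higher number that more compound is tolerated), compound 2 `C[C@@H](NC(=O)c1nc(-c2ccccn2)nc(O)c1O)C1CCCCC1` gives 3200 nM, second highest of three numbers. Compound 1 `O=C(NCCC1CCCCC1)c1nc(-c2ccccn2)nc(O)c1O` gives 4200 nM, within the scatter of compound 2, and compound 3 `C[C@H](NC(=O)c1nc(-c2ccccn2)nc(O)c1O)C1CCCCC1` gives 600 nM. Compound 4 `Cc1ccnc(-c2nc(O)c(O)c(C(=O)N[C@H](C)C3CCCCC3)n2)c1` turns pyridin-2-yl into 4-methylpyridin-2-yl, with methyl in place of hydrogen on an aromatic carbon. The measured steps all concern the amide side: a 1.3-fold lower number from compound 1 to compound 2 (0.12 log units; within the scatter) lies within the scatter and a 5.3-fold lower number from compound 2 to compound 3 (0.73 log units; beyond the scatter) beyond it, the latter resting on (the fact that compounds 2 and 3 differ only in the configuration as drawn). None touches the aromatic ring carrying the methyl, so no shift beyond the scatter is expected. The expected change is a 1.1-fold lower number from compound 2 to compound 4 (0.03 log units; within the scatter), without a firm direction. Compound 4 is estimated at 3000 nM, within a range of 1100 nM to 7000 nM.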

Compound 4, half-maximal cytotoxic concentration: 2700 nM
Compound 4: middle estimate off by 1.1-fold (0.05 log units), on the high side; low and high end bracket the measured number.
By their numbers in this assay, from the lowest: compound 3; then compounds 4, 2 and 1 (each within the scatter of the next).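

Unlike the earlier steps, all on the amide side, this change lies on the aromatic ring. In this assay, going from pyridin-2-yl to 4-methylpyridin-2-yl gives a 1.2-fold lower number from compound 2 to compound 4 (0.07 log units; within the scatter), so this position accepts a methyl without a shift beyond the scatter, at least with the amide side of compound 2. Nothing available bears on a cause for this step.

From the compounds shown here alone, whether a larger group here, such as trifluoromethyl or an amine, would stay as close remains open. Also open, going by these compounds, is whether the same methyl would leave compound 3 similarly unchanged.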